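This account rests on a few compounds, and the source may have more. Where it says the series, first, only, none or still open, it means among the compounds named here.

Of the compounds shown here, three sharing one core have been measured so far in an ADME assay on Vero cells (Chlorocebus sabaeus) for cytotoxicity, read by MTT assay, with a stated time of 72 h (a higher number here means that more compound is needed for the effect, a lower number that less compound is needed), on this scale. Compound 1 `Cc1cccc(C(=O)Nc2nc(-c3ccccn3)cs2)c1` gives 4100 nM and compound 2 `O=C(Nc1nc(-c2ccccn2)cs1)c1ccccc1Br` gives 3500 nM here, and a 1.2-fold lower number from compound 1 to compound 2 (0.07 log units; within the scatter) leaves the two indistinguishable. Compound 3 `O=C(Nc1nc(-c2ccccn2)cs1)c1cccc(F)c1` gives 1200 nM as the lowest number of the three. It stands apart from both others, with a 3.4-fold lower number from compound 1 to compound 3 (0.53 log units; beyond the scatter) and a 2.9-fold lower number from compound 2 to compound 3 (0.46 log units; beyond the scatter) as modest steps.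

Compound 4 `O=C(Nc1nc(-c2ccccn2)cs1)c1cccnc1Cl` has not been measured yet. It keeps the shared core and differs from compound 3 in one place, and the change is 2-chloropyridin-3-yl in place of 3-fluorophenyl on a carbonyl carbon on a carbonyl carbon, 2-chloropyridin-3-yl in place of 3-fluorophenyl. Among the measured compounds shown here, no measured step brings in a ring with a hetero atom, so the evidence is indirect. Only compound 3 carries the 3-fluorophenyl group, and the two other groups measured at this place both give higher numbers. By name, the nearest match to the incoming group is the 2-bromophenyl of compound 2 at 3500 nM on the same scale. A modest move toward a higher number is therefore expected, estimated as a 2.5-fold higher number from compound 3 to compound 4 (0.40 log units; beyond the scatter) in size. Compound 4 is estimated at 3000 nM with an expected range from 1000 nM to 9000 nM as the likely span.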

Compound 4, half-maximal effective concentration: 1900 nM
Beside the measured number, compound 4's estimate is 1.6-fold (0.20 log units) above it; the measured number falls inside the stated range.
By their numbers in this assay, from the lowest: compounds 3, 4, 2 and 1 (each within the scatter of the next, the first and the last beyond it).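

Among the compounds shown here, at this place on the carbonyl carbon, a ring with a hetero atom appears for the first time, and in this assay the number stays in the range of the carbon-only rings. With a 1.6-fold higher number from compound 3 to compound 4 (0.20 log units; within the scatter) and a 1.8-fold lower number from compound 2 to compound 4 (0.27 log units; within the scatter) both within the scatter, compound 4 cannot be told apart from compound 3 or from compound 2, even though those two stand apart from each other; only a 2.2-fold lower number from compound 1 to compound 4 (0.33 log units; beyond the scatter) goes beyond the scatter, and it is a modest step. Nothing shown explains why the 2-chloropyridin-3-yl group gives this result.

The ring nitrogen and the chlorine enter together in compound 4, so the compounds shown cannot say which of the two, if either, shapes the number. From the compounds shown here alone, what an amine or a carboxylic acid on the ring would do, or a longer chain at this place on the carbonyl carbon instead of a ring, also stays open.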